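3-Chlorobenzyl to Propyl: A Step Still Unmeasured

This account rests on a few compounds, and the source may have more. Where it says the series, first, only, none or still open, it means among the compounds named here.

Compound 1 `C#CCOc1cc(O)c2c(c1)O[C@H](c1ccc(OC)c(O)c1)CC2=O`: 20900 nM
Compound 2 `COc1ccc([C@@H]2CC(=O)c3c(O)cc(OCc4cn(Cc5cccc(Cl)c5)nn4)cc3O2)cc1O`: 18200 nM

In a functional assay on RAW264.7 cells (Mus musculus) for inhibition, read by Griess assay, with stated times of 2 h and 24 h (a lower number here means a stronger inhibitor, a higher number a weaker inhibitor), compound 2 gives 18200 nM and compound 1 gives 20900 nM. These two values lie within the usual scatter of each other, so compound 2 stands level with compound 1 on the numbers available.

Compound 3 `CCCn1cc(COc2cc(O)c3c(c2)O[C@H](c2ccc(OC)c(O)c2)CC3=O)nn1` has not yet been measured. It differs from compound 2 by ethyl in place of 3-chlorophenyl on a saturated chain carbon bound to an aromatic nitrogen. Read one bond further out, the same change turns 3-chlorobenzyl into propyl.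

Among the measured compounds shown here, no step between measured compounds speaks directly to this change, so in this assay no step beyond the scatter is expected, in either direction. The expected step of a 1.1-fold higher number from compound 2 to compound 3 (0.04 log units; within the scatter) is only an estimate. Compound 3 is estimated at 20000 nM, with an expected range of 9000 nM to 45000 nM.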

Compound 3, half-maximal inhibitory concentration: 9670 nM
Compound 3: middle estimate off by 2.1-fold (0.32 log units), on the high side; low and high end bracket the measured number.
By their numbers in this assay, from the lowest: compounds 3, 2 and 1 (each within the scatter of the next, the first and the last beyond it).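

In this assay, ethyl in place of 3-chlorophenyl on a saturated chain carbon bound to an aromatic nitrogen gives a 1.9-fold lower number from compound 2 to compound 3 (0.27 log units; within the scatter), so this position tolerates the loss of the aromatic ring and its chlorine without a step beyond the scatter. The 1-propyl-1H-1,2,3-triazol-4-yl group in place of ethynyl, on a saturated chain carbon bound to an oxygen on an aromatic ring, gives a 2.2-fold lower number from compound 1 to compound 3 (0.33 log units; beyond the scatter), a modest step and the only one here that passes beyond the scatter. Nothing at hand gives a cause for either step.

From the compounds shown here alone, it remains open whether a longer chain such as hexyl, or a chain ending in an amine or a carboxylic acid, would read differently from propyl. Also open, going by these compounds, is how plain benzyl would compare with 3-chlorobenzyl at this position.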